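Pyridin-2-yl for Phenyl on the Ring Nitrogen

A few compounds are considered here, and "the series" means these few. Any claim that something is new, unique, unknown or untested is made for them only; others in the source may bear on it.

In an assay on isolated protein for inhibition of MAP kinase-activated protein kinase 5 (Homo sapiens), read by mobility shift assay, tested at 30 uM (on this read-out higher numbers stand for more inhibition at the one concentration tested (going by the name of the read-out) and lower numbers for less inhibition), compound 2 `Nc1c2c(=O)[nH]c(-c3ccccc3)cc2nn1-c1ccccc1` gives 22%, the highest of the three numbers; compound 1 `CC(C)(C)c1cc2nn(-c3ccccc3)c(N)c2c(=O)[nH]1` gives 2% and compound 3 `Nc1c2c(=O)[nH]c(-c3ccccn3)cc2nn1-c1ccccc1` gives 2%, the two of them within the scatter of each other. Compound 4 `Nc1c2c(=O)[nH]c(-c3ccccc3)cc2nn1-c1ccccn1` differs from compound 2 by pyridin-2-yl in place of phenyl on an aromatic nitrogen. The step that bears on this swap is the same exchange made on the aromatic carbon, a number 20 percentage points lower from compound 2 to compound 3 (beyond the scatter); alongside it, a number 20 percentage points higher from compound 1 to compound 2 (beyond the scatter) shows that the phenyl bearer alone stands apart, and no change at the digits printed from compound 1 to compound 3 (within the scatter) shows no movement. Because a number 20 percentage points lower from compound 2 to compound 3 (beyond the scatter) cost inhibition, a modest loss in this assay is expected for compound 4, estimated as a number 12 percentage points lower from compound 2 to compound 4 (beyond the scatter). Compound 4 is therefore expected to give 10%, within 0% to 25%.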

Compound 4, a percentage reported as inhibition, at one concentration (the size of the read-out at that concentration, not a potency): -1%
Beside the measured number, compound 4's estimate is 11 percentage points above it, and the stated range ends above it.
By their numbers in this assay, from the lowest: compounds 4, 1 and 3 (each within the scatter of the next); then compound 2.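

In this assay, pyridin-2-yl in place of phenyl on the aromatic nitrogen brings a number 23 percentage points lower from compound 2 to compound 4 (beyond the scatter). The earlier compounds shown here showed this loss only for the same exchange on the aromatic carbon, so compound 2, with phenyl at both places, now stands apart from single exchanges at either one. Nothing measured here explains the loss. From the compounds shown here alone, whether an amine or a carboxylic acid on the phenyl at this nitrogen would add inhibition stays open, as does what a methyl group on this nitrogen would give.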